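The source may report more compounds than this note shows. Statements on the series, on what has been measured and on what is new or still open speak of the compounds shown alone.

Compound 1 `CC1CCN(C2CCN(S(=O)(=O)c3cccc(-c4ccccc4F)c3)CC2)CC1` gives > 5000 nM in an ADME assay on HCT-116 cells (Homo sapiens) for cytotoxicity, read by CellTiter-Glo, with a stated time of 72 h (on this read-out higher numbers stand for weaker inhibition and lower numbers for stronger inhibition), a limit of the assay.
Compound 2 `CC1CCN(C2CCN(S(=O)(=O)c3ccc(C(C)C)cc3)CC2)CC1` gives > 5000 nM in this assay, a limit of the assay.
Compound 3 `Cc1ccc(C2CCN(S(=O)(=O)c3c(C)cc(C)cc3C)CC2)cc1` gives > 5000 nM in this assay, a limit of the assay.

Compound 2 stands where every measured compound stands on this read-out: at a limit, not at a number. For the measured compounds named here, the three values shown are all limits of the same kind, so no ordering among compound 1, compound 2 and compound 3 can be read from them, and no step between any pair is given.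

The move from compound 2 to compound 4 `CC1CCN(C2CCN(S(=O)(=O)c3ccc(OC(F)(F)F)cc3)CC2)CC1` is a single change on the aromatic ring: trifluoromethoxy in place of isopropyl on an aromatic carbon. Compound 4 has not yet been measured in this assay.

Going by the values given here, no measured step exists to guide the expectation, so it rests on what the measured values show. Because (the limit of > 5000 nM in this assay, at which 3 of the 3 values shown sit), every compound in this set sits beyond the reach of the assay, and the exchange of one substituent for another on the same aromatic carbon gives no reason, on these numbers, to expect a departure from that picture. The expected step that the limit leaves unreadable from compound 2 to compound 4 is therefore none beyond the scatter. Compound 4 is expected to give 8000 nM in this assay, within a range from 3000 nM to 30000 nM, most likely reported again as a limit rather than as a number.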

Compound 4, half-maximal inhibitory concentration: > 5000 nM
Compound 4 gave a limit, no number; the forecaster's own chance of this, stated with the estimate: 80%; the middle value is on the limit's open side.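

In this assay compound 4 gives > 5000 nM, a limit of the assay. For the compounds shown here, compound 2 also stands at a limit, so no step between compound 2 and compound 4 can be read. The compounds shown leave open how far each lies past that limit, and whether any compound of this kind would give a number on this read-out.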